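A Hexenyl Nucleoside Expected from a Hydroxypropynyl Precursor

This account rests on a few compounds, and the source may have more. Where it says the series, first, only, none or still open, it means among the compounds named here.

In an ADME assay on L1210/0 cells (Mus musculus) for cytotoxicity, with a stated time of 48 h (on this read-out higher numbers stand for weaker inhibition and lower numbers for stronger inhibition), compound 1 `O=c1ccn([C@@H]2O[C@H](CO)[C@H](F)[C@@H]2O)c(=O)[nH]1` gives > 200000 nM, which is a limit of the assay rather than a number. Compound 2 `O=c1[nH]c(=O)n([C@H]2C[C@H](O)[C@@H](CO)O2)cc1C#CCO` gives > 200000 nM in this assay, again a limit. Going by the values given here, compound 2 therefore stands at the limit of > 200000 nM in this assay, at which 2 of the 2 values shown sit, and no measured step connects it to another compound. Compound 3 `CCCC/C=C\c1cn([C@H]2C[C@H](O)[C@@H](CO)O2)c(=O)[nH]c1=O` differs from compound 2 by hex-1-en-1-yl in place of 3-hydroxyprop-1-yn-1-yl on an aromatic carbon. Among the compounds with values here, with no measured step to lean on, the author expects the change to stay within the scatter or leave the read-out at the limit. The estimated value for compound 3 in this assay is 150000 nM, within 30000 nM to 400000 nM. The step expected is an at least 1.3-fold lower number from compound 2 to compound 3 (0.12 log units; that floor lies within the scatter).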

Compound 3, half-maximal inhibitory concentration: > 200000 nM
Compound 3 was reported as a limit; the forecaster's own chance of this, stated with the estimate: 70%; middle value at least 1.3-fold (0.12 log units) away from the limit.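

Going by these compounds alone, compound 2 and compound 3 both stand at a limit in this assay, and no step between them can be read. The compounds shown leave open which change to the shared core, if any, would give a readable number in this assay: the limit of > 200000 nM in this assay, at which 3 of the 3 values shown sit.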